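A few compounds are considered here, and "the series" means these few. Any claim that something is new, unique, unknown or untested is made for them only; others in the source may bear on it.

Measured in a functional assay on SMMC-7721 cells (Homo sapiens) for antiproliferative activity, read by MTT assay, with a stated time of 48 h; on this read-out lower numbers stand for stronger inhibition and higher numbers for weaker inhibition:
compound 1 `COC/C1=C/C[C@](C)(CCC=C(C)C)/C=C/[C@@H](OC(=O)C=C(C)C)[C@](C)(O)/C=C/C1=O`, where compound 1 gives 11000 nM
compound 2 `CC(C)=CCC[C@]1(C)/C=C/[C@@H](OC(=O)C=C(C)C)[C@](C)(O)/C=C/C(=O)/C(CN2CCCC2)=C\C1`, where compound 2 gives 140 nM
compound 3 `CC[Si](CC)(CC)C/C1=C/C[C@](C)(CCC=C(C)C)/C=C/[C@@H](OC(=O)C=C(C)C)[C@](C)(O)/C=C/C1=O`, where compound 3 gives 3460 nM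

Compound 1 carries the highest number of the three; compound 3 stands nearest to it and compound 2 furthest. Compound 4 `CC(C)=CCC[C@]1(C)/C=C/[C@@H](OC(=O)C=C(C)C)[C@](C)(O)/C=C/C(=O)/C(CN=[N+]=[N-])=C\C1` differs from compound 1 in one place: azido in place of methoxy on a saturated chain carbon bound to a double-bonded ring carbon. Within the data shown here, two measured steps bear on this position: a 79-fold lower number from compound 1 to compound 2 (1.90 log units; beyond the scatter) and a 3.2-fold lower number from compound 1 to compound 3 (0.50 log units; beyond the scatter). Both replacements of the methoxy at this carbon gave lower numbers, one large and one modest. Azido is neither the pyrrolidin-1-yl of compound 2 nor the silicon-bearing group of compound 3, so a modest downward step is expected, a 2.8-fold lower number from compound 1 to compound 4 (0.44 log units; beyond the scatter). In this assay compound 4 is estimated at 4000 nM, with a range from 1500 nM to 11000 nM.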

Compound 4, half-maximal inhibitory concentration: 3080 nM
For compound 4 the middle estimate is 1.3-fold (0.11 log units) above the measured one; measured number inside the range.
By their numbers in this assay, from the lowest: compound 2; then compounds 4 and 3 (each within the scatter of the next); then compound 1.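

Azido also gives a lower number than methoxy at this carbon (a 3.6-fold lower number from compound 1 to compound 4 (0.55 log units; beyond the scatter)), so all three replacements shown point the same way. Azido and the silicon-bearing group of compound 3 cannot be told apart (a 1.1-fold lower number from compound 3 to compound 4 (0.05 log units; within the scatter)), even though they have no atoms in common. Pyrrolidin-1-yl remains clearly separate from azido (a 22-fold higher number from compound 2 to compound 4 (1.34 log units; beyond the scatter)), so it alone gives a large step here.

Going by these compounds, whether that large step needs the ring or only an amine nitrogen stays open; diethylamino or piperidin-1-yl at this carbon would test this. Nothing at hand accounts for the gap between pyrrolidin-1-yl and the other groups.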